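A Longer Chain on the Shared Core: Compound 3

The source may report more compounds than this note shows. Statements on the series, on what has been measured and on what is new or still open speak of the compounds shown alone.

Compound 1 `COCc1cc(COc2ccc([C@]3(N)CCN([C@H](CC(C)C)C(=O)NO)C3=O)cc2)c2ccccc2n1`: 1240 nM
Compound 2 `Cc1cc(COc2ccc([C@]3(N)CCN([C@H](CC(C)C)C(=O)NO)C3=O)cc2)c2ccccc2n1`: 466 nM

Of the compounds shown here, two have been measured in an assay on isolated protein for inhibition of Matrilysin (Homo sapiens), read by FRET; on this read-out lower numbers stand for stronger inhibition and higher numbers for weaker inhibition. For the measured compounds named here, compound 2 stands at the lowest of the two numbers; its nearest neighbour is compound 1, and the only measured step, a 2.7-fold lower number from compound 1 to compound 2 (0.43 log units; beyond the scatter), shows that stripping the methoxy from the chain on the shared core gave a modest gain.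

Compound 3 `COCCc1cc(COc2ccc([C@]3(N)CCN([C@H](CC(C)C)C(=O)NO)C3=O)cc2)c2ccccc2n1` takes the opposite road from compound 2: methoxymethyl in place of hydrogen on a saturated chain carbon bound to an aromatic carbon. Seen one bond further out, the change reads methyl to 2-methoxyethyl, so compound 3 carries a chain one carbon longer than compound 1 and again bearing a methoxy. Going by the values given here, the single step that bears on this, from compound 1 to compound 2, ran in favour of the shorter, methoxy-free chain; no measured pair tells how a longer methoxy-bearing chain behaves. Compound 3 is therefore expected to give a number above compound 2, estimated as a step of a 1.9-fold higher number from compound 2 to compound 3 (0.29 log units; within the scatter) in this assay. Compound 3 is expected to reach about 900 nM, with a range from 400 nM to 2000 nM.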

Compound 3, half-maximal inhibitory concentration: 1010 nM
Estimate against measurement, compound 3: 1.1-fold (0.05 log units) below; the range from low to high includes it.
By their numbers in this assay, from the lowest: compound 2; then compounds 3 and 1 (each within the scatter of the next).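

Moving from methyl to 2-methoxyethyl on the saturated chain carbon bound to an aromatic carbon also raises the number in this assay, with a 2.2-fold higher number from compound 2 to compound 3 (0.34 log units; beyond the scatter), so a second methoxy-bearing chain now stands on the same side of compound 2 as the first. Against the shorter methoxy-bearing chain, the longer one gives no difference that can be told apart, with a 1.2-fold lower number from compound 1 to compound 3 (0.09 log units; within the scatter), and the two chains read as level at this position. Among these three compounds, the plain methyl of compound 2 therefore keeps the lowest number, beyond the scatter of both others, while the added carbon between the two methoxy-bearing chains shows no effect of its own, and nothing available offers a reason for this pattern.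

The compounds shown do not separate the effect of the chain's oxygen from that of its length, and a plain ethyl or propyl chain at this place would be needed to tell the two apart. From the compounds shown here alone, how an amine or a hydroxyl at the end of the chain would read in this assay also remains open.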